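Ring swap on the double-bonded chain carbon of compound 1

The source may report more compounds than this note shows. Statements on the series, on what has been measured and on what is new or still open speak of the compounds shown alone.

For the measured compounds named here, compound 1 `C=CCn1c(=O)/c(=C\c2cccc(F)c2)[nH]c(=O)/c1=C\c1ccccc1OC`, in a functional assay on MCF7 cells (Homo sapiens) for cytotoxicity, read by CCK-8 assay, with a stated time of 72 h (on this read-out higher numbers stand for weaker inhibition and lower numbers for stronger inhibition), gives 13700 nM, the lowest of the two numbers so far. Compound 3 `C=CCn1c(=O)/c(=C\c2cc(Br)ccc2F)[nH]c(=O)/c1=C\c1ccccc1OC`, which carries 5-bromo-2-fluorophenyl in place of 3-fluorophenyl on the double-bonded chain carbon bound to an aromatic carbon, gives 28100 nM in this assay; the step is a 2.1-fold higher number from compound 1 to compound 3 (0.31 log units; beyond the scatter). Compound 2 `C=CCn1c(=O)/c(=C\c2ccc(Cl)c(Cl)c2)[nH]c(=O)/c1=C\c1ccccc1OC` is reported as "not active" (no number reported) in this assay, so no number stands for it.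

Compound 4 `C=CCn1c(=O)/c(=C\c2ccc(C)cc2)[nH]c(=O)/c1=C\c1ccccc1OC` differs from compound 1 by 4-methylphenyl in place of 3-fluorophenyl on a double-bonded chain carbon bound to an aromatic carbon. Going by the values given here, the one step that bears on this place, a 2.1-fold higher number from compound 1 to compound 3 (0.31 log units; beyond the scatter), was modest and ran to a higher number, and compound 2, also changed at this place, returned no number at all. Neither exchange tried there has improved on compound 1. A 4-methylphenyl ring has not been measured, so the expectation rests on those two outcomes: a modest rise or no change beyond the scatter, with some chance that compound 4 too is reported only as not active. Compound 4 is expected to give 22000 nM in this assay, within 9000 nM to 60000 nM, which means the estimated step of a 1.6-fold higher number from compound 1 to compound 4 (0.21 log units; within the scatter).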

Compound 4, half-maximal inhibitory concentration: "not active" (no number reported)
The entry for compound 4 holds no number; there is nothing to compare the estimate with.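

For the compounds shown here, compound 4 is reported as "not active" in this assay, so no step from compound 1 to compound 4 can be read. Nothing at hand accounts for this outcome. Left open is whether any ring at this place improves on compound 1 at 13700 nM.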